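Hydroxymethyl in Place of Sec-Butyl: an Expected Tail Flick Result

The source may report more compounds than this note shows. Statements on the series, on what has been measured and on what is new or still open speak of the compounds shown alone.

Of the compounds shown here, three have so far been tested in a functional assay on the whole organism (Tail, strain ICR) with Mus musculus as the target, in the tail flick test, with a stated time of 90 min, at a dose of 25 umol/kg by the oral route; a lower number here means a weaker effect, a higher number a stronger effect of the compound at the dose given. Compound 1 `O=C(CN(c1nc(Cl)nc2[nH]cnc12)C1CC1)N[C@@H](CO)C(=O)OCc1ccccc1` gives 34.5% in this assay. Compound 2 `O=C(O)[C@@H]1CCCN1C(=O)CN(c1nc(Cl)nc2[nH]cnc12)C1CC1` gives 26%. Compound 3 `CC[C@H](C)[C@H](NC(=O)CN(c1nc(Cl)nc2[nH]cnc12)C1CC1)C(=O)O` gives 27.4%, a number that lies close to that of compound 2 and a little further from that of compound 1, yet both gaps stay within the usual scatter, so no order among the three can be read from these numbers.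

Compound 4 `O=C(CN(c1nc(Cl)nc2[nH]cnc12)C1CC1)N[C@@H](CO)C(=O)O` has not yet been measured in this assay. It differs from compound 3 in one place: hydroxymethyl in place of sec-butyl on a saturated chain carbon bound to an amide-type nitrogen and a carbonyl carbon. Among the measured compounds shown here, no pair of measured compounds isolates this change, so its effect cannot be read from the numbers at hand; what the three measured numbers do show is that the three different amino-acid-derived side chains give results within the scatter of one another. The step from compound 3 to compound 4 is therefore expected to be small, a number 0.6 percentage points higher from compound 3 to compound 4 (within the scatter), with no direction claimed beyond the scatter. For compound 4 the estimated value in this assay is 28%, within a range of 15% to 42%.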

Compound 4, a percentage reported as activity, at one dose (the size of the read-out at that dose, not a potency): 43.9%
Compound 4: the middle estimate sits 15.9 percentage points below what was measured, and the stated range ends below it.
By their numbers in this assay, from the lowest: compounds 2, 3, 1 and 4 (each within the scatter of the next, the first and the last beyond it).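

In this assay hydroxymethyl in place of sec-butyl on this saturated chain carbon gives a number 16.5 percentage points higher from compound 3 to compound 4 (beyond the scatter) and so shows what the three earlier numbers could not: the read-out responds to the group at this position. Replacing 2-carboxypyrrolidin-1-yl on a carbonyl carbon with (1-carboxy-2-hydroxyethyl)amino gives a number 17.9 percentage points higher from compound 2 to compound 4 (beyond the scatter) as a second step of this kind. Hydrogen in place of benzyl on an oxygen next to a carbonyl group gives a number 9.4 percentage points higher from compound 1 to compound 4 (within the scatter) and thus does not separate the benzyl ester from the carboxylic acid.

Nothing available explains these steps. Still open, as far as these compounds go, is whether a plain methyl, an aminomethyl or a longer hydroxyethyl chain on the same carbon would hold the number of compound 4 or return it to that of compound 3.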